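Replacing 1H-1,2,4-triazol-1-yl with dimethylamino in compound 2

The compounds below may be only part of what the source reports. "The series", "measured", "known", "first", "only" and "open" are said of these compounds alone.

In a functional assay on OVCAR-8 cells (Homo sapiens) for antiproliferative activity (a lower number here means a stronger inhibitor, a higher number a weaker inhibitor), compound 1 `Cn1ncc(Cl)c1-c1cc(C(=O)N[C@@H]2CN[C@H](CCN3CCC(O)CC3)C[C@H]2c2ccc(Cl)c(Cl)c2)oc1Cl` gives 15900 nM, compound 2 `Cn1ncc(Cl)c1-c1cc(C(=O)N[C@@H]2CN[C@H](CCn3cncn3)C[C@H]2c2ccc(Cl)c(Cl)c2)oc1Cl` gives 1560 nM and compound 3 `CNC(=O)C[C@@H]1C[C@@H](c2ccc(F)c(F)c2)[C@H](NC(=O)c2cc(-c3c(Cl)cnn3C)c(Cl)o2)CN1` gives 800 nM. The values of compound 2 and compound 3 thus lie within the usual scatter of each other, while compound 1 stands well apart with the highest number of the three.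

Compound 4 `CN(C)CC[C@@H]1C[C@@H](c2ccc(Cl)c(Cl)c2)[C@H](NC(=O)c2cc(-c3c(Cl)cnn3C)c(Cl)o2)CN1` keeps the rest of compound 2 and changes one group: dimethylamino in place of 1H-1,2,4-triazol-1-yl on a saturated chain carbon, two bonds along the chain from a saturated ring carbon. Going by the values given here, one measured step bears on this place: a 10-fold lower number from compound 1 to compound 2 (1.01 log units; beyond the scatter), on exchanging 4-hydroxypiperidin-1-yl for 1H-1,2,4-triazol-1-yl. Read backwards, that large step suggests that leaving the triazolyl group for an amine could raise the number. However, dimethylamino is not the group in compound 1, and this single pair cannot show how much of the gap would carry over. Compound 3 differs from compound 2 in more than one place and offers no clean comparison.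

In this assay, the expected step is therefore a moderate rise, smaller than that large step: a 2.2-fold higher number from compound 2 to compound 4 (0.35 log units; beyond the scatter). The estimate for compound 4 is 3500 nM, with an expected range of 1000 nM to 12000 nM.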

Compound 4, half-maximal inhibitory concentration: 1510 nM
Compound 4: the middle estimate sits 2.3-fold (0.37 log units) above what was measured, and the stated range covers the measured number.
By their numbers in this assay, from the lowest: compounds 3, 4 and 2 (each within the scatter of the next); then compound 1.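

In this assay the exchange at this position gives a 1.0-fold lower number from compound 2 to compound 4 (0.01 log units; within the scatter) and so does not separate the 2-(dimethylamino)ethyl chain from the 2-(1H-1,2,4-triazol-1-yl)ethyl chain, even though dimethylamino has no ring and 1H-1,2,4-triazol-1-yl is a five-membered aromatic ring. The earlier pair could not show whether the gap to compound 1 was tied to the triazolyl group, but the new comparison gives an 11-fold lower number from compound 1 to compound 4 (1.02 log units; beyond the scatter) and is large, as is a 10-fold lower number from compound 1 to compound 2 (1.01 log units; beyond the scatter); compound 1, with 4-hydroxypiperidin-1-yl, stands apart from both, so an amine on this chain does not by itself bring the high number of compound 1. Nothing measured here offers a reason for these results.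

What the compounds leave open is whether the high number of compound 1 goes with the piperidine ring or with its hydroxyl group, which a plain piperidin-1-yl or a morpholin-4-yl group on the same chain would help to separate. They also leave open how far this insensitivity extends, whether to a carboxylic acid at this place or to a longer chain carrying dimethylamino.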